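Thiophene for Phenyl on Two Related Nucleoside Cores

This account rests on a few compounds, and the source may have more. Where it says the series, first, only, none or still open, it means among the compounds named here.

Of the compounds shown here, three have been measured in a functional assay on CEM-DNR-bulk cells (Homo sapiens), read by MTT assay, with a stated time of 72 h; a higher number here means a weaker inhibitor, a lower number a stronger inhibitor. Compound 3 `COc1ncnc2c1c(-c1ccccc1)cn2[C@@H]1O[C@H](CO)[C@@H](O)[C@H]1O` carries a phenyl group; in this assay compound 3 reaches only the limit of the assay, > 20000 nM. Compound 1 `COc1ncnc2c1c(-c1cccs1)cn2[C@@H]1O[C@H](CO)[C@@H](O)[C@H]1O` differs by thiophen-2-yl in place of phenyl on an aromatic carbon, and in this assay compound 1 gives 12100 nM. The change made an at least 1.6-fold lower number from compound 3 to compound 1 (0.21 log units; that floor lies within the scatter), and the step has only a floor because of the limit of > 20000 nM in this assay, at which 2 of the 3 values shown sit. Compound 2 `Nc1nc(N)c2c(-c3ccccc3)cn([C@@H]3O[C@H](CO)[C@@H](O)[C@H]3O)c2n1` has a different core; how the two cores differ is not broken down here. In this assay compound 2 also sits at the limit of the assay, > 20000 nM. Compound 4 `Nc1nc(N)c2c(-c3cccs3)cn([C@@H]3O[C@H](CO)[C@@H](O)[C@H]3O)c2n1` has not been measured; it differs from compound 2 by thiophen-2-yl in place of phenyl on an aromatic carbon, the same change as that from compound 3 to compound 1, made at the same place. Within the data shown here, the estimated step is an at least 1.3-fold lower number from compound 2 to compound 4 (0.12 log units; that floor lies within the scatter), resting on an at least 1.6-fold lower number from compound 3 to compound 1 (0.21 log units; that floor lies within the scatter) as the only measured precedent. Compound 4 is therefore expected near 15000 nM, within 6000 nM to 40000 nM, with a fair chance that only a limit is reported.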

Compound 4, half-maximal inhibitory concentration: > 20000 nM
Compound 4 gave a limit, no number; the forecaster's own chance of this, stated with the estimate: 50%; at least 1.3-fold (0.12 log units) between middle value and limit.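

No step can be read from compound 2 to compound 4, because both values in this assay are limits and not numbers: the limit of > 20000 nM in this assay, at which 3 of the 4 values shown sit.

The compounds shown leave open whether thiophen-2-yl in place of phenyl on an aromatic carbon changes the number at all on the core of compound 2.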